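This account rests on a few compounds, and the source may have more. Where it says the series, first, only, none or still open, it means among the compounds named here.

Measured so far in an assay for binding affinity to Amine oxidase [flavin-containing] A (Homo sapiens); on this read-out higher numbers stand for weaker inhibition and lower numbers for stronger inhibition:
compound 1, `CC(C)(C)OC(=O)c1cn(C[C@H]2CN(c3ccc(C4=CCS(=O)(=O)CC4)c(F)c3)C(=O)O2)nn1`: 3500 nM
compound 2, `C[Si](C)(C)C#Cc1cn(C[C@H]2CN(c3ccc(C4=CCS(=O)(=O)CC4)c(F)c3)C(=O)O2)nn1`: > 200000 nM, which is a limit of the assay and not a number.

Compound 1 stands as the only number shown in this assay; the one further value is a limit. The step of an at least 57-fold higher number from compound 1 to compound 2 (1.75 log units; beyond the scatter) runs out at the limit of > 200000 nM in this assay, at which 1 of the 2 values shown sits, so its true size is known only as a lower bound.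

Compound 3, `O=C1O[C@@H](Cn2cc(Br)nn2)CN1c1ccc(C2=CCS(=O)(=O)CC2)c(F)c1`, is not yet measured. It differs from compound 1 by bromo in place of tert-butoxycarbonyl on an aromatic carbon. For the measured compounds named here, the only measured step that bears on it is the one from compound 1 to compound 2, which exchanges the same tert-butoxycarbonyl on the same aromatic carbon for a different group and gives the large weakening noted above; it speaks for the place of change but not for bromo itself, and a single limit gives no scale. A weakening beyond the scatter is therefore expected, of uncertain size. The estimate for compound 3 in this assay is 15000 nM, with a range from 3000 nM to 100000 nM. That estimate for compound 3 means an expected step of a 4.3-fold higher number from compound 1 to compound 3 (0.63 log units; beyond the scatter).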

Compound 3, inhibition constant: 16000 nM
The estimate for compound 3 lay 1.1-fold (0.03 log units) below the measured number; measured number inside the range.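

In this assay, this aromatic carbon of the five-membered ring now has a second replacement of tert-butoxycarbonyl with a true size: the step of a 4.6-fold higher number from compound 1 to compound 3 (0.66 log units; beyond the scatter) is a measured difference, whereas the earlier step gave only a lower bound. Compound 3 also shows that a measurable number at this position does not depend on tert-butoxycarbonyl, since bromo, with 0 hydrogen-bond acceptors, still gives one, although compound 1 keeps the lowest number of the three. The value of compound 2, > 200000 nM, is a limit of the assay and not a number, so the step of an at least 12-fold lower number from compound 2 to compound 3 (1.09 log units; beyond the scatter) is also known only as a lower bound: the limit of > 200000 nM in this assay, at which 1 of the 3 values shown sits.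

The three groups differ in heavy atoms, hydrogen-bond acceptors and atom types all at once, so these compounds cannot separate which of these features goes with the changes in the number. On these data alone, how an amine, a carboxylic acid or a methyl ester would read on this carbon remains open, as does whether any group here can give a lower number than compound 1.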